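Trifluoromethyl in place of carboxy: expected shift

The source may hold more compounds than are shown below. What is called first, only, known or untested is meant among the compounds shown, and "the series" means these compounds.

Among the compounds with values here, compound 1 `O=C(O)c1cccc(CNc2cc(C(F)(F)F)cc3[nH]ncc23)c1` is the reference point of the two compounds measured so far. In an assay for inhibition of Tryptophan 2,3-dioxygenase (Homo sapiens), with stated times of 10 min and 60 min (on this read-out higher numbers stand for weaker inhibition and lower numbers for stronger inhibition), compound 1 gives 1690 nM, the lower of the two numbers recorded. Compound 2 `O=[N+]([O-])c1cc(OCc2ccccc2)ccc1CNc1cc(C(F)(F)F)cc2[nH]ncc12` gives 97000 nM in this assay, a higher number that lies beyond the scatter. Compound 2 differs from compound 1 in more than one place, so the two values stand side by side without a single step connecting them.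

Compound 3 `FC(F)(F)c1cccc(CNc2cc(C(F)(F)F)cc3[nH]ncc23)c1` is still to be measured in this assay. It differs from compound 1 in one place: trifluoromethyl in place of carboxy on an aromatic carbon. Within the data shown here, no measured pair in the set shows a change of this kind, so the size of the step rests on judgement. Among the measured compounds shown here, the group that leaves carries a hydrogen-bond donor and acceptor and the group that enters carries neither, and the only other compound without a carboxy, compound 2, gives the higher number already noted, though not through a single change.

The step is estimated as a 3.0-fold higher number from compound 1 to compound 3 (0.47 log units; beyond the scatter), towards weaker inhibition, beyond the scatter but not large. Compound 3 is expected to give 5000 nM, within a range of 1500 nM to 20000 nM.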

Compound 3, half-maximal inhibitory concentration: 12200 nM
Compound 3: middle estimate off by 2.4-fold (0.39 log units), on the low side; the range from low to high includes it.
By their numbers in this assay, from the lowest: compound 1; then compound 3; then compound 2.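

The change of trifluoromethyl in place of carboxy on an aromatic carbon, meta to a large group, gives a 7.2-fold higher number from compound 1 to compound 3 (0.86 log units; beyond the scatter) in this assay. Within the data shown here, this is the first single-place step, and it shows that the number responds to the group carried at this position. The change also removes the hydrogen-bond donor and acceptor counted for carboxy without ending the read-out, since compound 3 still gives 12200 nM, but no measurement at hand bears on why the number rises.

With only one replacement at this position, the step cannot be divided between the loss of carboxy and the entry of trifluoromethyl; a plain hydrogen, a nitrile or a primary amide in the same place would be needed to tell these apart. As far as these compounds go, it also remains open whether the lower number of compound 1 depends on the free carboxylic acid itself, as a methyl ester or a carboxylic acid on a longer chain could show.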